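Selenium to Sulfur on a Second Core: Expecting Compound 4

A few compounds are considered here, and "the series" means these few. Any claim that something is new, unique, unknown or untested is made for them only; others in the source may bear on it.

Compound 1 `C[Se]/C(=N\C(=O)c1cc2ccccc2s1)NC(=O)c1cc2ccccc2s1` and compound 3 `CS/C(=N\C(=O)c1cc2ccccc2s1)NC(=O)c1cc2ccccc2s1` share one core. In a functional assay on K562 cells (Homo sapiens) for cytotoxicity, read by MTT assay, with a stated time of 72 h (on this read-out higher numbers stand for weaker inhibition of growth and lower numbers for stronger inhibition of growth), compound 1 gives 61000 nM, and compound 3 gives 66600 nM. The change between them is a group of 2 heavy atoms (1 carbon, 1 sulfur; no ring) in place of a group of 2 heavy atoms (1 carbon, 1 selenium; no ring), on a carbon with a double bond to nitrogen, and the step it made was a 1.1-fold higher number from compound 1 to compound 3 (0.04 log units; within the scatter). Compound 2 `C[Se]/C(=N\C(=O)c1ccco1)NC(=O)c1ccco1` rests on a different core; the difference between the two cores is not broken down here. In this assay compound 2 gives only a limit of the assay, > 100000 nM. Compound 4 `CS/C(=N\C(=O)c1ccco1)NC(=O)c1ccco1` arises from compound 2 by the same change, (a group of 2 heavy atoms (1 carbon, 1 sulfur; no ring) in place of a group of 2 heavy atoms (1 carbon, 1 selenium; no ring), on a carbon with a double bond to nitrogen). The step from compound 2 to compound 4 is expected to be a step that the limit leaves unreadable from compound 2 to compound 4, because the same change gave a 1.1-fold higher number from compound 1 to compound 3 (0.04 log units; within the scatter). Compound 4 is therefore expected to give about 150000 nM, most likely again only a limit, in a range from 70000 nM to 400000 nM.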

Compound 4, concentration for total growth inhibition: > 100000 nM
Compound 4 ended at the assay's limit; the forecaster's own chance of this, stated with the estimate: 75%; the middle value lies beyond the limit too.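

No step from compound 2 to compound 4 can be read, because both values are limits of the assay and not numbers: the limit of > 100000 nM in this assay, at which 2 of the 4 values shown sit.

Still open, on these data alone, is whether methylsulfanyl in place of the selenium-bearing group changes growth inhibition at all on the core of compound 2.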